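The source may report more compounds than this note shows. Statements on the series, on what has been measured and on what is new or still open speak of the compounds shown alone.

Measured in a functional assay on A549 cells (Homo sapiens) for cytotoxicity, read by MTT assay, with a stated time of 48 h; a lower number here means a stronger inhibitor, a higher number a weaker inhibitor:

compound 1 `Cc1ccc(S(=O)(=O)/N=C(/CCNC2=CC(=O)c3ccccc3C2=O)Nc2ccc(Cl)cc2)cc1`: 29900 nM
compound 2 `Cc1ccc(S(=O)(=O)/N=C(/CCNC2=CC(=O)c3ccccc3C2=O)Nc2ccc(F)cc2)cc1`: 9330 nM
compound 3 `Cc1ccc(S(=O)(=O)/N=C(/CCNC2=CC(=O)c3ccccc3C2=O)Nc2ccccc2[N+](=O)[O-])cc1`: 5010 nM

Among these three numbers compound 2 stands second highest. Its nearest neighbour is compound 3, and the two values lie within the scatter of each other: a 1.9-fold lower number from compound 2 to compound 3 (0.27 log units; within the scatter). Its furthest neighbour is compound 1, a weaker inhibitor, and that gap is beyond the scatter: a 3.2-fold lower number from compound 1 to compound 2 (0.51 log units; beyond the scatter).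

The step taken here leads from compound 2 to compound 4 `Cc1ccc(S(=O)(=O)/N=C(/CCNC2=CC(=O)c3ccccc3C2=O)NC(C)C)cc1`. The change is isopropyl in place of 4-fluorophenyl on an amine nitrogen. Every step measured so far swaps one aromatic group on that amine nitrogen for another aromatic group; the largest of them, a 6.0-fold lower number from compound 1 to compound 3 (0.78 log units; beyond the scatter), was modest, and the other two were modest or within the scatter. Among the measured compounds shown here, no measured step exchanges an aromatic group for a short chain such as isopropyl, so none bears directly on this change. For the measured compounds named here, with only that indirect guidance, the expectation in this assay is a step of modest size at most, in either direction, quite possibly within the scatter.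

Compound 4 is therefore estimated at 15000 nM, with a range from 5000 nM to 45000 nM. That estimate corresponds to an expected step of a 1.6-fold higher number from compound 2 to compound 4 (0.21 log units; within the scatter).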

Compound 4, half-maximal inhibitory concentration: 44300 nM
Estimate against measurement, compound 4: 3.0-fold (0.47 log units) below; low and high end bracket the measured number.
By their numbers in this assay, from the lowest: compounds 3 and 2 (each within the scatter of the next); then compounds 1 and 4 (each within the scatter of the next).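

Among the compounds shown here, this is the first change at this amine nitrogen that removes the aromatic ring altogether, and in this assay the effect depends on which ring is removed: isopropyl gives a clear loss against the 4-fluorophenyl group (a 4.7-fold higher number from compound 2 to compound 4 (0.68 log units; beyond the scatter)) and against the 2-nitrophenyl group (an 8.8-fold higher number from compound 3 to compound 4 (0.95 log units; beyond the scatter)). The 4-chlorophenyl compound goes against any rule that an aromatic ring here always beats a short chain, since its step stays within the scatter (a 1.5-fold higher number from compound 1 to compound 4 (0.17 log units; within the scatter)). The position therefore tolerates isopropyl no worse than one aromatic group, so what sits on the ring matters as much as whether a ring is present, but no measurement in hand explains why these numbers differ.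

The compounds shown leave open whether the loss follows from removing a ring as such, which a cyclohexyl group on the same nitrogen would help to test, or from the shorter reach of isopropyl, which a longer chain such as n-butyl would address. They also leave open how an unsubstituted phenyl group, or a chain ending in an amine or a carboxylic acid, would behave here.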